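The source may report more compounds than this note shows. Statements on the series, on what has been measured and on what is new or still open speak of the compounds shown alone.

Two compounds of a shared core, each carrying a triazole ring, have been tested for their power to kill breast cancer cells. In a functional assay on MCF7 cells (Homo sapiens) for cytotoxicity, read by MTT assay, with a stated time of 48 h (on this read-out higher numbers stand for weaker inhibition and lower numbers for stronger inhibition), compound 1 `CC(C)=CCC/C(C)=C/CC/C(C)=C/CC[C@@H]1[C@@]2(C)CC/C(=N\OCc3cn(-c4ccccc4C#N)nn3)C(C)(C)[C@@H]2CC[C@@]1(C)O` gives 24900 nM. Compound 2 `CC(C)=CCC/C(C)=C/CC/C(C)=C/CC[C@@H]1[C@@]2(C)C/C(=C\c3ccc(OCc4cn(-c5ccccc5)nn4)cc3)C(=O)C(C)(C)[C@@H]2CC[C@@]1(C)O`, in which the triazole is attached through a phenyl ring with an unsubstituted phenyl on the far side, gives 23000 nM in this assay. These two numbers lie within the usual scatter of each other, so on the evidence at hand compound 2 cannot be set apart from compound 1.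

Compound 3 `CC(C)=CCC/C(C)=C/CC/C(C)=C/CC[C@@H]1[C@@]2(C)C/C(=C\c3ccc(OCc4cn(-c5cccc([N+](=O)[O-])c5)nn4)cc3)C(=O)C(C)(C)[C@@H]2CC[C@@]1(C)O` keeps the whole skeleton of compound 2 and differs in one respect: nitro in place of hydrogen on an aromatic carbon, which reads as phenyl becoming 3-nitrophenyl. For the measured compounds named here, no measured pair shows what such a change does here, so the expected step of a 1.1-fold lower number from compound 2 to compound 3 (0.04 log units; within the scatter) is none beyond the scatter in either direction. Compound 3 is therefore estimated at 21000 nM in this assay, with a range from 8000 nM to 55000 nM.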

Compound 3, half-maximal inhibitory concentration: 79400 nM
Beside the measured number, compound 3's estimate is 3.8-fold (0.58 log units) below it; the measured number lies above the stated range.
By their numbers in this assay, from the lowest: compounds 2 and 1 (each within the scatter of the next); then compound 3.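

For the compounds shown here, until this result, no measured pair showed whether the phenyl on the triazole could take a new group without consequence. In this assay there is now one such pair: nitro in place of hydrogen, meta to a large group, gives a 3.5-fold higher number from compound 2 to compound 3 (0.54 log units; beyond the scatter) and so weaker inhibition, which shows that this ring position is not indifferent to what it carries, though the step is modest and rests on this single pair. Nothing measured here explains why the number rises.

On these data alone, whether an amine, a methoxy group or a carboxylic acid on the same aromatic carbon would move the number in the same direction remains open. So does the question of whether nitro on a different carbon of that ring would give a similar step.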